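Swapping a methoxyphenyl for difluorophenyl on a pyrazole chalcone

The source may report more compounds than this note shows. Statements on the series, on what has been measured and on what is new or still open speak of the compounds shown alone.

Of the compounds shown here, three have been measured in a functional assay on NCI-H322M cells (Homo sapiens) for cytotoxicity, read by sulforhodamine B assay, with a stated time of 48 h, tested at 100 uM; a lower number here means a stronger effect, a higher number a weaker effect of the compound at the concentration tested. Compound 1 `COc1ccc(-c2cc(/C=C/C(=O)c3ccc(N)cc3)[nH]n2)cc1OC` gives -88%, and compound 2 `COc1ccc(-c2cc(/C=C/C(=O)c3cc(OC)c(OC)c(OC)c3)[nH]n2)cc1OC` gives -91%. Compound 3 `COc1ccc(C(=O)/C=C/c2cc(-c3cc(OC)c(OC)c(OC)c3)n[nH]2)cc1` gives -31%, the highest of the three numbers and therefore the weakest effect shown, well beyond the scatter from both others.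

Compound 4 `COc1cc(-c2cc(/C=C/C(=O)c3ccc(F)c(F)c3)[nH]n2)cc(OC)c1OC` differs from compound 3 in one place: 3,4-difluorophenyl in place of 4-methoxyphenyl on a carbonyl carbon. For the measured compounds named here, no measured pair tells how this kind of exchange moves the read-out, so the expectation rests on the spread of the three numbers alone. Compound 4 is estimated at -45%, with a range from -85% to -5%, which would mean an expected step of a number 14 percentage points lower from compound 3 to compound 4 (beyond the scatter) in this assay, a moderate lowering that may or may not exceed the scatter.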

Compound 4, a percentage reported as activity, at one concentration (the size of the read-out at that concentration, not a potency): 3%
Compound 4: the middle estimate sits 48 percentage points below what was measured, and the stated range ends below it.
By their numbers in this assay, from the lowest: compounds 2 and 1 (each within the scatter of the next); then compound 3; then compound 4.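

This is the only pair shown that differs in one place, and in this assay the group on the carbonyl carbon clearly matters: 3,4-difluorophenyl in place of 4-methoxyphenyl gives a number 34 percentage points higher from compound 3 to compound 4 (beyond the scatter) and so a weaker effect at the concentration tested. Nothing measured here explains why the exchange has this effect. The pair cannot separate losing the methoxy group from adding the two fluorines. It also leaves open whether a plain phenyl or a chlorophenyl at this place would keep the effect of compound 3.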